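A few compounds are considered here, and "the series" means these few. Any claim that something is new, unique, unknown or untested is made for them only; others in the source may bear on it.

Measured in a functional assay on HT-29 cells (Homo sapiens) for cytotoxicity, read by MTT assay, with a stated time of 72 h (a lower number here means a stronger inhibitor, a higher number a weaker inhibitor), the compounds read as follows
compound 1 `O=C(CN1CCN(c2nnc(Cc3ccccc3)c3ccccc23)CC1)Nc1c(F)cccc1F` gives 19700 nM
compound 2 `O=C(CN1CCN(c2nnc(Cc3ccncc3)c3ccccc23)CC1)Nc1cccc(F)c1` gives 6130 nM
compound 3 `Cc1ccccc1NC(=O)CN1CCN(c2nnc(Cc3ccccc3)c3ccccc23)CC1` gives 113000 nM

Compound 3 carries the highest number of these three, and its gaps to the other two both lie beyond the scatter. Compound 4 `O=C(CN1CCN(c2nnc(Cc3ccccc3)c3ccccc23)CC1)Nc1cccc(F)c1` keeps the rest of compound 3 and changes one group, with 3-fluorophenyl in place of 2-methylphenyl on an amide-type nitrogen as the whole difference.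

Among the compounds with values here, one measured step bears on this directly. That step, a 5.7-fold higher number from compound 1 to compound 3 (0.76 log units; beyond the scatter), brings the same 2-methylphenyl onto that nitrogen and is modest in size. Losing that group may therefore be expected to lower the number by a similar amount. Compound 2 gives 6130 nM with the 3-fluorophenyl in place, but it differs from compound 4 elsewhere, so it offers only loose support. The expected change is a 7.5-fold lower number from compound 3 to compound 4 (0.88 log units; beyond the scatter), a drop estimated to lie beyond the scatter. Compound 4 is estimated at 15000 nM (expected range 5000 nM to 45000 nM).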

Compound 4, half-maximal inhibitory concentration: 95000 nM
Compound 4: the middle estimate sits 6.3-fold (0.80 log units) below what was measured; measured number outside the range, above it.
By their numbers in this assay, from the lowest: compound 2; then compound 1; then compounds 4 and 3 (each within the scatter of the next).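

In this assay, the swap on the amide-type nitrogen gives a 1.2-fold lower number from compound 3 to compound 4 (0.08 log units; within the scatter), so the numbers do not separate 2-methylphenyl from 3-fluorophenyl at this place, and the earlier drop seen with 2,6-difluorophenyl cannot be read as a general result of losing 2-methylphenyl; 2,6-difluorophenyl stands apart from 3-fluorophenyl too, with a 4.8-fold higher number from compound 1 to compound 4 (0.68 log units; beyond the scatter). With 3-fluorophenyl held on that nitrogen, the change on the saturated chain carbon, phenyl in place of pyridin-4-yl, gives a 15-fold higher number from compound 2 to compound 4 (1.19 log units; beyond the scatter), a large step that shows compound 2 owes its low number to that other place rather than to 3-fluorophenyl. Nothing on hand accounts for these steps.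

The compounds shown leave open whether pyridin-4-yl gives a similar step with 2,6-difluorophenyl or 2-methylphenyl on the nitrogen. They also leave open how an unsubstituted phenyl or a 4-methoxyphenyl would read at that place.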